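Two Fluorines in Place of One on the Amide Ring

The source may hold more compounds than are shown below. What is called first, only, known or untested is meant among the compounds shown, and "the series" means these compounds.

Compound 1 `O=C(Nc1cccc(-c2oc3cc(-c4ccc(F)cc4)ccc3c(=O)c2O)c1)c1ccccc1F` carries an amide whose carbonyl bears a 2-fluorophenyl group. In a functional assay on HeLa cells (Homo sapiens) for antiproliferative activity, read by CCK-8 assay, with a stated time of 72 h (a higher number here means a weaker inhibitor, a lower number a stronger inhibitor), compound 1 gives 5630 nM, the second highest of the three numbers recorded. Its nearest neighbour is compound 2 `Cc1cccc(C(=O)Nc2cccc(-c3oc4cc(-c5ccc(F)cc5)ccc4c(=O)c3O)c2)c1`, which in this assay gives 6650 nM; the step is a 1.2-fold higher number from compound 1 to compound 2 (0.07 log units; within the scatter). Furthest away is compound 3 `O=C(Nc1cccc(-c2oc3cc(-c4ccc(F)cc4)ccc3c(=O)c2O)c1)c1ccc(Cl)nc1`, which gives 4080 nM, a step of a 1.4-fold lower number from compound 1 to compound 3 (0.14 log units; within the scatter). Between these two, the step of a 1.6-fold lower number from compound 2 to compound 3 (0.21 log units; within the scatter) is likewise within the scatter.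

Compound 4 `O=C(Nc1cccc(-c2oc3cc(-c4ccc(F)cc4)ccc3c(=O)c2O)c1)c1cc(F)cc(F)c1` differs from compound 1 only at the same position: 3,5-difluorophenyl in place of 2-fluorophenyl on a carbonyl carbon. Every measured step in this set exchanges the aryl group on that carbonyl carbon, and none of them moves the number beyond the scatter, whether the incoming ring carries a methyl, a ring nitrogen with chlorine, or fluorine. The account therefore expects no step beyond the scatter for compound 4 either, with no direction that the data can support.

Compound 4 is estimated to give 5000 nM, with a range from 2500 nM to 10000 nM. This estimate corresponds to an expected step of a 1.1-fold lower number from compound 1 to compound 4 (0.05 log units; within the scatter).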

Compound 4, half-maximal inhibitory concentration: 3380 nM
Compound 4: the middle estimate sits 1.5-fold (0.17 log units) above what was measured; the range from low to high includes it.
By their numbers in this assay, from the lowest: compounds 4, 3, 1 and 2 (each within the scatter of the next).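

Adding a second fluorine and placing the two as 3,5-difluorophenyl on the carbonyl carbon does not take the number in this assay beyond the scatter (a 1.7-fold lower number from compound 1 to compound 4 (0.22 log units; within the scatter)), and exchanging the 6-chloropyridin-3-yl group for this ring does not either (a 1.2-fold lower number from compound 3 to compound 4 (0.08 log units; within the scatter)). The step from the 3-methylphenyl amide, the largest step yet seen at this position, also stays within the scatter (a 2.0-fold lower number from compound 2 to compound 4 (0.29 log units; within the scatter)), so all four aryl groups on this carbonyl carbon remain indistinguishable here, and the number of fluorines on the ring shows no measurable effect in this set. No measurement is available that could explain the result or tie it to any property of the 3,5-difluorophenyl group.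

What the compounds shown leave open is whether a group other than a six-membered aromatic ring on this carbonyl carbon, such as a cyclohexyl ring or a longer alkyl chain, or an aryl ring bearing an amine or a carboxylic acid, would move the number beyond the scatter. Nor do they show what a change elsewhere on the shared core would do.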